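The source may hold more compounds than are shown below. What is called first, only, known or untested is meant among the compounds shown, and "the series" means these compounds.

Compound 1 `CCCCCc1cn(C/C=C(/C)CC/C=C(\C)CCC=C(C)C)nn1` gives 7.5
Compound 2 `CC(C)=CCC/C(C)=C/Cn1cc(-c2ccccc2)nn1` gives 4.91

In a physicochemical assay for lipophilicity, measured as octanol-water partition (a lower number here means a more polar compound, a higher number a more lipophilic compound), compound 1 stands highest of the two measured compounds at 7.5 and compound 2 lies lower at 4.91 on the same scale. The gap between these two compounds lies beyond the scatter. Compound 3 `CCCc1cn(C/C=C(/C)CC/C=C(\C)CCC=C(C)C)nn1` is still unmeasured and differs from compound 1 by hydrogen in place of ethyl on a saturated chain carbon, three bonds along the chain from an aromatic carbon with hydrogen in place of ethyl on a saturated chain carbon, three bonds along the chain from an aromatic carbon, so pentyl becomes propyl. Going by the values given here, no measured pair shows this change alone, so the direction and size are only an expectation. The expected step in this assay is a number 1.00 log units lower from compound 1 to compound 3 (beyond the scatter) and it is expected to point downward, beyond the scatter. Compound 3 is estimated at 6.5 with an expected range from 6.1 to 6.9 on this scale.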

Compound 3, partition coefficient: 6.5
Beside the measured number, compound 3's estimate shows no gap at the digits printed; low and high end bracket the measured number.
By their numbers in this assay, from the lowest: compound 2; then compound 3; then compound 1.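

Compound 1 and compound 3 differ in one place only, so this assay can now be read for a single change: pentyl becoming propyl gives a number 1.00 log units lower from compound 1 to compound 3 (beyond the scatter) and shows that the length of this chain alone moves the number. Compound 2 could not show this, as it differs from compound 1 in more than one place. Nothing measured here gives the cause of this step. Still open, on these data alone, is whether butyl would fall between these two compounds, and how a longer chain such as hexyl, or an amine in place of pentyl, would move the number.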